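The source may hold more compounds than are shown below. What is called first, only, known or untested is meant among the compounds shown, and "the series" means these compounds.

Measured so far:
compound 1 `CC(C(=O)NCc1ccc(C(F)(F)F)nc1Cl)c1ccc(NS(C)(=O)=O)c(F)c1` — 0.2 nM
compound 2 `CC(C(=O)NCc1ccc(C(F)(F)F)nc1C1=CCC(C(C)(C)C)CC1)c1ccc(NS(C)(=O)=O)c(F)c1` — 0.2 nM
compound 3 `CCC/C=C\c1nc(C(F)(F)F)ccc1CNC(=O)C(C)c1ccc(NS(C)(=O)=O)c(F)c1` — 2.1 nM

In an assay on CHO cells for antagonist activity at transient receptor potential cation channel subfamily V member 1 (Homo sapiens), read by FLIPR and calcium flux (a higher number here means a weaker inhibitor, a lower number a stronger inhibitor), compound 1 stands level with compound 2 at the digits shown, the two together giving the lowest numbers of the three; the furthest is compound 3, at an 11-fold higher number from compound 1 to compound 3 (1.02 log units; beyond the scatter). Compound 4 `CC(C(=O)NCc1ccc(C(F)(F)F)nc1/C=C/C1CCCCC1)c1ccc(NS(C)(=O)=O)c(F)c1` is not yet measured. It differs from compound 1 in one place: 2-cyclohexylethenyl in place of chloro on an aromatic carbon. For the measured compounds named here, two measured steps bear on this. Replacing the chloro by a group carrying a six-membered non-aromatic ring gave no change at the digits printed from compound 1 to compound 2 (within the scatter), while replacing it by an open-chain group with a double bond outside aromatic rings gave an 11-fold higher number from compound 1 to compound 3 (1.02 log units; beyond the scatter). The entering group of compound 4 carries both a ring and such a double bond, so the outcome is expected to lie between these two steps, most likely a modest rise beyond the scatter. Compound 4 is therefore expected near 0.8 nM, between 0.25 nM and 3 nM. That would correspond to an expected step of a 4.0-fold higher number from compound 1 to compound 4 (0.60 log units; beyond the scatter) in this assay.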

Compound 4, inhibition constant: 0.7 nM
The estimate for compound 4 lay 1.1-fold (0.06 log units) above the measured number, and the stated range covers the measured number.
By their numbers in this assay, from the lowest: compounds 1 and 2 (each within the scatter of the next); then compound 4; then compound 3.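

In this assay, the 2-cyclohexylethenyl group on this aromatic carbon, next to the ring nitrogen, falls short of both chloro (a 3.5-fold higher number from compound 1 to compound 4 (0.54 log units; beyond the scatter)) and 4-(tert-butyl)cyclohex-1-en-1-yl (a 3.5-fold higher number from compound 2 to compound 4 (0.54 log units; beyond the scatter)), so carrying a six-membered non-aromatic ring does not by itself keep the number level with compound 1. It still improves on the open-chain pent-1-en-1-yl (a 3.0-fold lower number from compound 3 to compound 4 (0.48 log units; beyond the scatter)), which shows that groups with one double bond outside aromatic rings separate beyond the scatter at this position. Nothing available explains this order.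

The compounds shown leave open what 2-cyclohexylethyl, with the same ring and no double bond, would give here. Also open, on these data alone, is how an amine such as piperidin-1-yl would compare with chloro on this carbon.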